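Replacing 3,4-dichlorophenyl by 3,4-difluorophenyl on a Carbonyl

The source may report more compounds than this note shows. Statements on the series, on what has been measured and on what is new or still open speak of the compounds shown alone.

Three measured compounds share one core and differ in the groups attached to it. In a functional assay on SK-MEL-28 cells (Homo sapiens) for cytotoxicity, read by sulforhodamine B assay, with a stated time of 48 h, tested at 1 uM (on this read-out lower numbers stand for a stronger effect and higher numbers for a weaker effect at the one concentration tested), compound 1 `COc1ccc(-c2cc(/C=C/C(=O)c3ccc(OC)c(OC)c3)[nH]n2)cc1` gives 90%, compound 3 `COc1ccc(-c2cc(/C=C/C(=O)c3cc(OC)c(OC)c(OC)c3)[nH]n2)cc1OC` gives 89%, and compound 2 `COc1cc(-c2cc(/C=C/C(=O)c3ccc(Cl)c(Cl)c3)[nH]n2)cc(OC)c1OC` gives 114%. Compound 2 thus stands highest of the three, beyond the scatter from both compound 1 and compound 3, which lie within the scatter of each other. Compound 4 `COc1cc(-c2cc(/C=C/C(=O)c3ccc(F)c(F)c3)[nH]n2)cc(OC)c1OC` has not yet been measured; it differs from compound 2 in one place: 3,4-difluorophenyl in place of 3,4-dichlorophenyl on a carbonyl carbon. Within the data shown here, no step between measured compounds is available to calibrate this change. Because compound 2 gives 114%, a number near the top of the read-out, compound 4 is expected to show only a small step, a number 12 percentage points lower from compound 2 to compound 4 (beyond the scatter), not beyond the scatter. Compound 4 is therefore estimated at 102%, within 85% to 120%.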

Compound 4, a percentage reported as activity, at one concentration (the size of the read-out at that concentration, not a potency): 98%
The estimate for compound 4 lay 4 percentage points above the measured number; low and high end bracket the measured number.
By their numbers in this assay, from the lowest: compounds 3, 1 and 4 (each within the scatter of the next); then compound 2.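

Among these compounds, replacing 3,4-dichlorophenyl by 3,4-difluorophenyl on the carbonyl carbon gives a number 16 percentage points lower from compound 2 to compound 4 (beyond the scatter) in this assay and is the first single-place step available here, showing that the read-out responds to a change at this position alone. Both groups have the same count of heavy atoms and the same aromatic ring, so the step follows the exchange of chlorine for fluorine. No measurement shown explains this step.

On these data alone, whether a phenyl group carrying an amine or a carboxylic acid on this carbonyl carbon would shift the number further remains open. So does whether the same exchange gives a similar step with other groups on the shared core.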